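Changing the Group at the Saturated Chain Carbon

A few compounds are considered here, and "the series" means these few. Any claim that something is new, unique, unknown or untested is made for them only; others in the source may bear on it.

Measured so far in a functional assay on HeLa cells (Homo sapiens) for inhibition, with a stated time of 72 h; on this read-out higher numbers stand for an effect only at larger amounts of compound and lower numbers for an effect already at smaller amounts:
compound 1, `COc1cc(CNCc2ccncc2)ccc1OCc1ccc(C)cc1`: 5000 nM
compound 2, `COc1cc(CNCc2ccncc2)ccc1OCc1ccc(Cl)nc1`: 400 nM
compound 3, `COc1cc(CNCc2ccncc2)ccc1OCc1ccc(Cl)c(Cl)c1`: 4000 nM

Compound 3 gives the second highest of the three numbers. Its nearest neighbour is compound 1: a 1.3-fold lower number from compound 1 to compound 3 (0.10 log units; within the scatter). Its furthest is compound 2: a 10-fold higher number from compound 2 to compound 3 (1.00 log units; beyond the scatter).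

Compound 4 is `COc1cc(CNCc2ccncc2)ccc1OCc1ccc([N+](=O)[O-])cc1`. The change from compound 3 is 4-nitrophenyl in place of 3,4-dichlorophenyl on a saturated chain carbon bound to an oxygen on an aromatic ring. For the measured compounds named here, no measured step covers a nitro group, so the bearing steps are indirect. One step shows that a six-membered aromatic ring of carbon only with a methyl group and one with two chlorines sit close together: a 1.3-fold lower number from compound 1 to compound 3 (0.10 log units; within the scatter). The other shows that a ring with a nitrogen in it gives a markedly lower number: a 13-fold lower number from compound 1 to compound 2 (1.10 log units; beyond the scatter). Whether the two hydrogen-bond acceptors of 4-nitrophenyl behave like compound 2 or like compounds 1 and 3 cannot be read from these three compounds.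

Compound 4 is therefore estimated to lie between the two groups, a 1.6-fold lower number from compound 3 to compound 4 (0.20 log units; within the scatter), with a wide range: 2500 nM, from 600 nM to 10000 nM.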

Compound 4, half-maximal effective concentration: 440 nM
Compound 4: the middle estimate sits 5.7-fold (0.75 log units) above what was measured; measured number outside the range, below it.
By their numbers in this assay, from the lowest: compounds 2 and 4 (each within the scatter of the next); then compounds 3 and 1 (each within the scatter of the next).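

In this assay this position, the saturated chain carbon bound to an oxygen on an aromatic ring, turns out to reach the low level of compound 2 without a nitrogen inside the ring: the change gives a 9.1-fold lower number from compound 3 to compound 4 (0.96 log units; beyond the scatter) and, with nitro in place of methyl, an 11-fold lower number from compound 1 to compound 4 (1.06 log units; beyond the scatter). The two low compounds carry different groups, 4-nitrophenyl and 6-chloropyridin-3-yl, yet the comparison shows only a 1.1-fold higher number from compound 2 to compound 4 (0.04 log units; within the scatter). No measurement shown here explains why these two groups match or why they differ from those of compound 1 and compound 3.

From the compounds shown here alone, it remains open whether an amine or a carboxylic acid in place of the nitro group would hold this level. A longer chain between the ring and the oxygen is equally untested among the compounds shown.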